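The source may report more compounds than this note shows. Statements on the series, on what has been measured and on what is new or still open speak of the compounds shown alone.

Compound 1 `Cc1ccc(NC(=S)NC(=O)c2ccc(OCc3cccc(C(F)(F)F)c3)cc2)cc1-c1nc2ccccc2[nH]1`: 6050 nM
Compound 2 `Cc1ccc(NC(=S)NC(=O)c2ccc(OCc3ccccc3F)cc2)cc1-c1nc2ccccc2[nH]1`: 2420 nM

Of the compounds shown here, two have been measured in a functional assay on MNK45 cells (Homo sapiens) for inhibition, read by MTT assay, with a stated time of 48 h; a lower number here means a stronger inhibitor, a higher number a weaker inhibitor. Compound 2 holds the lower of the two numbers; its nearest neighbour is compound 1, and the single step that separates them, a 2.5-fold lower number from compound 1 to compound 2 (0.40 log units; beyond the scatter), lies beyond the scatter, so compound 2 is the stronger of the pair on the numbers shown. The unmeasured compound 3 `Cc1ccc(NC(=S)NC(=O)c2ccc(OCc3cccc(Cl)c3Cl)cc2)cc1-c1nc2ccccc2[nH]1` differs from compound 2 in one place only: 2,3-dichlorophenyl in place of 2-fluorophenyl on a saturated chain carbon bound to an oxygen on an aromatic ring. For the measured compounds named here, the only measured step that touches this place is a 2.5-fold lower number from compound 1 to compound 2 (0.40 log units; beyond the scatter), which shows that exchanging one substituted phenyl for another at this position can move the number by a modest but real amount. Going by the values given here, no measured step involves a 2,3-dichlorophenyl group, and nothing in the two values says in which direction a second halogen at this ring would push the number. The expectation for compound 3 is therefore a step of a 1.4-fold higher number from compound 2 to compound 3 (0.16 log units; within the scatter), with wide uncertainty on either side. Compound 3 is estimated to give 3500 nM in this assay, most likely between 1200 nM and 10000 nM.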

Compound 3, half-maximal inhibitory concentration: > 100000 nM
Compound 3 ended at the assay's limit (the forecaster's own chance of this, stated with the estimate: 5%); at least 28-fold (1.45 log units) between middle value and limit.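

The reading of compound 3 in this assay is a limit of the assay and not a number: the limit of > 100000 nM in this assay, at which 1 of the 3 values shown sits.

Even as a limit it changes the picture of this position, since the step of an at least 41-fold higher number from compound 2 to compound 3 (1.61 log units; beyond the scatter) and the step of an at least 16-fold higher number from compound 1 to compound 3 (1.21 log units; beyond the scatter) are both large, whereas the only earlier step, a 2.5-fold lower number from compound 1 to compound 2 (0.40 log units; beyond the scatter), was modest. The substituted phenyl on a saturated chain carbon bound to an oxygen on an aromatic ring therefore does more than adjust the number slightly: with the shared core unchanged, exchanging one substituted phenyl for 2,3-dichlorophenyl is enough to carry the reading to the limit.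

The compounds shown leave open whether a single chlorine on this phenyl ring would already have that effect or whether both chlorines of the 2,3-dichlorophenyl group are needed. They also leave open how an unsubstituted phenyl or a methoxy-bearing phenyl would read at this position, and how far beyond the limit the true value of compound 3 lies.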